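Does a Trifluoromethyl Group Matter When the Parent Is Inactive?

The source may hold more compounds than are shown below. What is called first, only, known or untested is meant among the compounds shown, and "the series" means these compounds.

Compound 1 `C=C(Br)C(=O)Nc1cccc(/C=C2\SC(=O)N(Cc3ccc(C(F)(F)F)cc3)C2=O)c1`: 870 nM
Compound 2 `Nc1cccc(/C=C2\SC(=O)N(Cc3ccccc3)C2=O)c1`: > 250000 nM
Compound 3 `C=C(Br)C(=O)Nc1cccc(/C=C2\SC(=O)N(Cc3ccccc3)C2=O)c1`: 810 nM

These values come from a functional assay on FM3A cells (Mus musculus) for cytotoxicity, read by cell counting, with a stated time of 2 days; on this read-out higher numbers stand for weaker inhibition and lower numbers for stronger inhibition. The value shown for compound 2 is a limit of the assay, not a number, as noted by the limit of > 250000 nM in this assay, at which 1 of the 3 values shown sits. Compound 3 and compound 1 differ by trifluoromethyl in place of hydrogen on an aromatic carbon, and that change produced a 1.1-fold higher number from compound 3 to compound 1 (0.03 log units; within the scatter). Compound 3 differs from compound 2 by hydrogen in place of (1-bromoethenyl)carbonyl on a nitrogen on an aromatic ring, where the measured step was an at least 300-fold lower number from compound 2 to compound 3 (2.48 log units; beyond the scatter).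

Compound 4 `Nc1cccc(/C=C2\SC(=O)N(Cc3ccc(C(F)(F)F)cc3)C2=O)c1` has not yet been measured. It differs from compound 2 by trifluoromethyl in place of hydrogen on an aromatic carbon, the same change as from compound 3 to compound 1, at the same place. The step from compound 2 to compound 4 is expected to be a step that the limit leaves unreadable from compound 2 to compound 4, resting on the step of a 1.1-fold higher number from compound 3 to compound 1 (0.03 log units; within the scatter) seen for this change. Compound 4 is expected to give about 300000 nM, most likely only a limit again, within 100000 nM to 1000000 nM.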

Compound 4, half-maximal inhibitory concentration: > 250000 nM
Compound 4 ended at the assay's limit; the forecaster's own chance of this, stated with the estimate: 85%; the middle value is on the limit's open side.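

In this assay compound 4 gives > 250000 nM, which is a limit of the assay and not a number. The step between compound 2 and compound 4 cannot be read, and it shows neither that trifluoromethyl carries over to this core unchanged nor that it does not: the limit of > 250000 nM in this assay, at which 2 of the 4 values shown sit. On these data alone, removing the (1-bromoethenyl)carbonyl group instead gives an at least 280-fold higher number from compound 1 to compound 4 (2.45 log units; beyond the scatter), a large step on both cores, though its exact size on each stays unknown: the same change on two cores in this assay, an at least 300-fold lower number (2.48 log units; beyond the scatter) from compound 2 to compound 3 and an at least 280-fold lower number (2.45 log units; beyond the scatter) from compound 4 to compound 1; the limit leaves it open whether they differ.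

Still open, as far as these compounds go, is whether a simple acetyl group on the nitrogen would serve as well as (1-bromoethenyl)carbonyl. Also open, from the compounds shown here alone, is how a nitrile or a methoxy group would fare in the place of trifluoromethyl.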